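Dipropylamino to oxanylmethyl-ethylamino on the fused core

The source may report more compounds than this note shows. Statements on the series, on what has been measured and on what is new or still open speak of the compounds shown alone.

Two compounds in the series have numbers in an assay on HEK293 cells for displacement of a labelled ligand from corticotropin-releasing factor receptor 1 (Homo sapiens), read by scintillation proximity assay, with a stated time of 2 h; on this read-out higher numbers stand for weaker inhibition and lower numbers for stronger inhibition. Compound 1 `CCCN(CCC)c1cccc2nc(Nc3c(C)cc(C)cc3C)c(=O)n(C)c12` gives 672 nM. Compound 2 `CCCN(CCC)c1cccc2nc(Oc3c(OC)cc(COC)cc3OC)c(C)cc12` gives 138 nM, the lower of the two numbers, and the gap between compound 1 and compound 2 lies beyond the usual scatter. Among the measured compounds shown here, no single-point step between measured compounds is available, so the next change is read against compound 2 alone.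

Compound 3 `CCN(CC1CCOCC1)c1cccc2nc(Oc3c(OC)cc(COC)cc3OC)c(C)cc12` differs from compound 2 in one place: ethyl((oxan-4-yl)methyl)amino in place of dipropylamino on an aromatic carbon. Nothing measured in the series bears on this kind of exchange at that position, and the remaining parts of compound 2 are kept unchanged.

The expectation is a step from compound 2 to compound 3 of a 1.3-fold higher number from compound 2 to compound 3 (0.12 log units; within the scatter) in this assay, that is, no change beyond the scatter in either direction. Compound 3 is therefore estimated at 180 nM, with a range from 60 nM to 550 nM, because compound 2 sits at 138 nM.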

Compound 3, half-maximal inhibitory concentration: 646 nM
Estimate against measurement, compound 3: 3.6-fold (0.55 log units) below, outside the stated range (above it).
By their numbers in this assay, from the lowest: compound 2; then compounds 3 and 1 (each within the scatter of the next).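

In this assay, the amino group on this aromatic carbon is not an interchangeable part of compound 2: ethyl((oxan-4-yl)methyl)amino in place of dipropylamino gives a 4.7-fold higher number from compound 2 to compound 3 (0.67 log units; beyond the scatter). This single-place step shows that the position responds to the choice of amino group, and that this exchange, which brings in a six-membered non-aromatic ring with one hetero atom, goes towards weaker inhibition. No measurement at hand accounts for the step.

The compounds shown leave open whether the step follows the ring oxygen, the ring itself or the loss of a propyl chain. Ethyl(cyclohexylmethyl)amino in the same place would separate the ring oxygen from the carbon ring, and an open-chain ether such as ethyl(3-methoxypropyl)amino would test the oxygen without the ring.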